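A few compounds are considered here, and "the series" means these few. Any claim that something is new, unique, unknown or untested is made for them only; others in the source may bear on it.

Compound 2 `Nc1scc(CN2CCN(c3ccc([N+](=O)[O-])cc3)CC2)c1C(=O)c1ccc(Cl)cc1` gives -13% in a functional assay on CHO cells with adenosine receptor A1 (Homo sapiens) as the target, read by cAMP accumulation and immunoassay, with a stated time of 6 min, tested at 0.1 uM; on this read-out lower numbers stand for a stronger effect and higher numbers for a weaker effect at the one concentration tested. Among the three measured compounds it stands second highest: compound 1 `Nc1scc(CN2CCN(c3ccc(Cl)cc3Cl)CC2)c1C(=O)c1ccc(Cl)cc1` gives -11%, and the move is a number 2 percentage points lower from compound 1 to compound 2 (within the scatter); compound 3 `Nc1scc(CN2CCN(c3c(F)cccc3F)CC2)c1C(=O)c1ccc(Cl)cc1` gives -23%, and the move is a number 10 percentage points lower from compound 2 to compound 3 (within the scatter). Going by the values given here, the only step beyond the scatter is a number 12 percentage points lower from compound 1 to compound 3 (beyond the scatter). Compound 4 `Nc1scc(CN2CCN(c3cccc(F)c3F)CC2)c1C(=O)c1ccc(Cl)cc1` differs from compound 2 in that (2,3-difluorophenyl in place of 4-nitrophenyl on an amine nitrogen in a ring). Among the compounds with values here, the step that bears most on this is the one from compound 2 to compound 3, in which the same 4-nitrophenyl group left and a difluorophenyl group entered, there a 2,6-difluorophenyl rather than the 2,3-difluorophenyl seen here; that step stayed within the scatter. Within the data shown here, no other measured step touches a 2,3-difluorophenyl group. A small shift, if any, toward a lower number is therefore expected, and the expected step is a number 5 percentage points lower from compound 2 to compound 4 (within the scatter). Compound 4 is estimated at -18%, with a range from -30% to -6%.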

Compound 4, a percentage reported as activity, at one concentration (the size of the read-out at that concentration, not a potency): -5.2%
For compound 4 the middle estimate is 12.8 percentage points below the measured one, and the stated range ends below it.
By their numbers in this assay, from the lowest: compounds 3, 2, 1 and 4 (each within the scatter of the next, the first and the last beyond it).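

At this position on the ring nitrogen, the two difluorophenyl groups are not interchangeable in this assay: 2,3-difluorophenyl in place of 2,6-difluorophenyl gives a number 17.8 percentage points higher from compound 3 to compound 4 (beyond the scatter), a step between groups with the same atoms. The new group does not separate from the other two, since the change from 4-nitrophenyl is a number 7.8 percentage points higher from compound 2 to compound 4 (within the scatter) and the change from 2,4-dichlorophenyl is a number 5.8 percentage points higher from compound 1 to compound 4 (within the scatter). Nothing at hand explains why the two difluorophenyl groups differ.

The compounds shown leave open whether 2,6-dichlorophenyl or 2,6-dimethylphenyl would give a number close to that of compound 3, or whether this is confined to the 2,6-difluorophenyl group. They also leave open where an unsubstituted phenyl or a 2-fluorophenyl group would fall in this series.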